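Sarcosine terminus replacing glutamate in the antifolate series

The compounds below may be only part of what the source reports. "The series", "measured", "known", "first", "only" and "open" are said of these compounds alone.

Compound 1, `C#CCN(Cc1ccc2nc(C)nc(O)c2c1)c1ccc(C(=O)N[C@@H](CCC(=O)O)C(=O)N[C@@H](CCC(=O)O)C(=O)O)cc1`, gives 4600 nM in a functional assay for inhibition, with Mus musculus as the target (a lower number here means a stronger inhibitor, a higher number a weaker inhibitor), the lowest of the three numbers recorded. Compound 2, `C#CCN(Cc1ccc2nc(C)nc(O)c2c1)c1ccc(C(=O)N[C@@H](CC(C)C(=O)O)C(=O)N[C@@H](CCC(=O)O)C(=O)O)cc1`, gives 14000 nM, and compound 3, `C#CCN(Cc1ccc2nc(C)nc(O)c2c1)c1ccc(C(=O)N[C@@H](CC(C)(C)C(=O)O)C(=O)N[C@@H](CCC(=O)O)C(=O)O)cc1`, gives 22000 nM; the related steps are a 3.0-fold higher number from compound 1 to compound 2 (0.48 log units; beyond the scatter) and a 4.8-fold higher number from compound 1 to compound 3 (0.68 log units; beyond the scatter), both weakening. Compound 4, `C#CCN(Cc1ccc2nc(C)nc(O)c2c1)c1ccc(C(=O)N[C@@H](CCC(=O)O)C(=O)N(C)CC(=O)O)cc1`, differs from compound 1 as follows: (carboxymethyl)(methyl)amino in place of (1,3-dicarboxypropyl)amino on a carbonyl carbon. This reaches further than the changes in compound 2 or compound 3, since a carboxyl and the amide hydrogen both go. Among the measured compounds shown here, no measured step covers this change exactly, but the two available steps point the same way, so a weakening beyond the scatter is expected: compound 4 is estimated at 20000 nM (range 6000 nM to 70000 nM), corresponding to an expected step of a 4.3-fold higher number from compound 1 to compound 4 (0.64 log units; beyond the scatter).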

Compound 4, half-maximal inhibitory concentration: 70000 nM
For compound 4 the middle estimate is 3.5-fold (0.54 log units) below the measured one; the range from low to high includes it.
By their numbers in this assay, from the lowest: compound 1; then compounds 2 and 3 (each within the scatter of the next); then compound 4.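

In this assay, the terminal group on the carbonyl carbon proves sensitive: (carboxymethyl)(methyl)amino in place of (1,3-dicarboxypropyl)amino gives a 15-fold higher number from compound 1 to compound 4 (1.18 log units; beyond the scatter) and is a large step. Among the compounds shown here, compounds 2 and 3 keep this terminus and change only the inner chain, so this is the first reading at this position. No available evidence accounts for the size of this step.

The change removes a carboxylic acid, the amide hydrogen and a stereocentre together, so their separate contributions remain unresolved. The (carboxymethyl)amino terminus, which keeps the amide hydrogen, would help separate them.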